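Carboxy replaced by a silicon-bearing group: compound 4

A few compounds are considered here, and "the series" means these few. Any claim that something is new, unique, unknown or untested is made for them only; others in the source may bear on it.

In a functional assay on HL-60 cells (Homo sapiens) for antiproliferative activity, read by MTT assay, with a stated time of 48 h (a higher number here means a weaker inhibitor, a lower number a stronger inhibitor), compound 1 (`CC(=O)OC/C1=C/C[C@](C)(CCC=C(C)C)/C=C/[C@@H](OC(=O)C=C(C)C)[C@](C)(OC(C)=O)/C=C/C1=O`) gives 3480 nM and compound 2 (`C=C1/C=C/C(=O)/C(CO)=C\C[C@](C)(CCC=C(C)C)/C=C/[C@H]1OC(=O)C=C(C)C`) gives 2810 nM, two values within the scatter of each other. Compound 3 (`CC(C)=CCC[C@]1(C)/C=C/[C@@H](OC(=O)C=C(C)C)[C@](C)(O)/C=C/C(=O)/C(C(=O)O)=C\C1`) gives > 10000 nM as a limit of the assay, not a number. Compound 4 (`CC[Si](CC)(CC)C/C1=C/C[C@](C)(CCC=C(C)C)/C=C/[C@@H](OC(=O)C=C(C)C)[C@](C)(O)/C=C/C1=O`) carries a silicon-bearing group in place of the carboxy group of compound 3, on a double-bonded ring carbon (a group of 8 heavy atoms (7 carbon, 1 silicon; no ring) in place of a group of 3 heavy atoms (1 carbon, 2 oxygen; no ring), on a double-bonded ring carbon). Without the carboxy group, compound 4 is expected to read close to compound 2 with its 2810 nM in the same assay. A step toward stronger inhibition is therefore expected in this assay (an at least 3.3-fold lower number from compound 3 to compound 4 (0.52 log units; beyond the scatter)). For compound 4 the estimated value is 3000 nM, with an expected range from 800 nM to 10000 nM in this series.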

Compound 4, half-maximal inhibitory concentration: 2810 nM
The estimate for compound 4 lay 1.1-fold (0.03 log units) above the measured number, within the range that was stated.
By their numbers in this assay, from the lowest: compounds 2, 4 and 1 (each within the scatter of the next). At a limit, above all of these: compound 3.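

In this assay, the silicon-bearing group in place of the carboxy group on the double-bonded ring carbon gives an at least 3.5-fold lower number from compound 3 to compound 4 (0.55 log units; beyond the scatter). This position therefore responds to the change, and a group of 8 heavy atoms with no hydrogen-bond donors is accepted there. The step has only a lower bound because compound 3 stands at a limit of the assay, not a number: the limit of > 10000 nM in this assay, at which 1 of the 4 values shown sits.

Going by these compounds, whether the step comes from losing the carboxy group or from the silicon-bearing group itself stays open. A primary amide or a plain butyl chain at this position on the same core would separate the two.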